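Replacing 2,4-dichlorophenyl with 2-methoxyphenyl in compound 1

This account rests on a few compounds, and the source may have more. Where it says the series, first, only, none or still open, it means among the compounds named here.

Within the data shown here, in a functional assay on MCF7 cells (Homo sapiens) for antiproliferative activity, read by MTT assay, with a stated time of 72 h (a higher number here means a weaker inhibitor, a lower number a stronger inhibitor), compound 1 `O=C(COc1ccc(C(=O)/C=C/c2ccc(Cl)cc2Cl)cc1)N[C@H]1CCOC1=O` gives 34400 nM, the only exact number so far. In this assay compound 2 `O=C1OCC[C@@H]1NC(=S)SCCOc1ccc([N+](=O)[O-])cc1` is recorded only as a limit, > 64000 nM. Compound 3 `COc1ccccc1/C=C/C(=O)c1ccc(OCC(=O)N[C@H]2CCOC2=O)cc1` departs from compound 1 at one place: 2-methoxyphenyl in place of 2,4-dichlorophenyl on a double-bonded chain carbon bound to a double-bonded chain carbon. It carries 2-methoxyphenyl in place of 2,4-dichlorophenyl on a double-bonded chain carbon bound to a double-bonded chain carbon. Among the measured compounds shown here, no measured pair tests this change, so the expected step is a 1.2-fold higher number from compound 1 to compound 3 (0.07 log units; within the scatter), none beyond the scatter in this assay. Compound 3 is estimated at 40000 nM, with an expected range of 15000 nM to 90000 nM.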

Compound 3, half-maximal inhibitory concentration: > 64000 nM
Compound 3: no number, only a limit; the forecaster's own chance of this, stated with the estimate: 35%; middle value at least 1.6-fold (0.20 log units) away from the limit.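

In this assay compound 3 is recorded only as a limit, > 64000 nM. Taking 2-methoxyphenyl in place of 2,4-dichlorophenyl gives an at least 1.8-fold higher number from compound 1 to compound 3 (0.26 log units; that floor lies within the scatter), so this first test of the position does not separate the two groups beyond the scatter. The full size of the step cannot be read, because the measurement ends at a limit: the limit of > 64000 nM in this assay, at which 2 of the 3 values shown sit.

As far as these compounds go, whether a plain phenyl or a pyridyl group at this place would give an exact number remains open. The compounds shown also do not separate the departure of the chlorine atoms from the arrival of the methoxy group.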